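Shortening the Ether Chain on a Nitrophenyl Sulfonamide

The source may hold more compounds than are shown below. What is called first, only, known or untested is meant among the compounds shown, and "the series" means these compounds.

Measured in an assay on SK-BR-3 cells for inhibition of Aromatase (Homo sapiens); on this read-out higher numbers stand for weaker inhibition and lower numbers for stronger inhibition:
Compound 1 `CC(C)Oc1cc([N+](=O)[O-])ccc1N(C)S(C)(=O)=O` gives 2810 nM.
Compound 2 `CCCCCCOc1cc([N+](=O)[O-])ccc1N(C)S(C)(=O)=O` gives 4490 nM.

Within the data shown here, only one step between measured compounds exists: hexyl in place of isopropyl on an oxygen on an aromatic ring, a 1.6-fold higher number from compound 1 to compound 2 (0.20 log units; within the scatter). Among the measured compounds shown here, that step lies within the scatter, so compound 2 and compound 1 cannot be told apart on these numbers; compound 2 simply holds one of the two values, and compound 1 is its only neighbour.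

Compound 3 `COc1cc([N+](=O)[O-])ccc1N(C)S(C)(=O)=O` has not yet been measured in this assay. Compared with compound 2 it carries hydrogen in place of pentyl on a saturated chain carbon bound to an oxygen on an aromatic ring. For the measured compounds named here, the single step that bears on it, a 1.6-fold higher number from compound 1 to compound 2 (0.20 log units; within the scatter), altered the group on the same oxygen on an aromatic ring in the opposite sense, from isopropyl to hexyl, and did not move the number beyond the scatter. Going the other way, from hexyl to methyl, the expected step of a 1.5-fold lower number from compound 2 to compound 3 (0.18 log units; within the scatter) is therefore judged to be no larger than the scatter, in neither direction. The estimate for compound 3 is 3000 nM, in a range from 1200 nM to 8000 nM.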

Compound 3, half-maximal inhibitory concentration: > 25000 nM
Compound 3: only a limit was reported; the forecaster's own chance of this, stated with the estimate: 5%; middle value at least 8.3-fold (0.92 log units) from the limit.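

Compound 3 carries methoxy where compound 2 carries hexyloxy. In this assay compound 3 gives > 25000 nM, and this value is a limit of the assay, not a number: the limit of > 25000 nM in this assay, at which 1 of the 3 values shown sits.

The earlier comparison of hexyl with isopropyl on this oxygen could not separate the two groups, so the group seemed to matter little, but the shortest chain behaves differently: there is an at least 5.5-fold higher number from compound 2 to compound 3 (0.74 log units; beyond the scatter), and there is also an at least 8.8-fold higher number from compound 1 to compound 3 (0.94 log units; beyond the scatter). Among these compounds, both steps lie beyond the scatter, so methyl stands apart from isopropyl and from hexyl on this oxygen, with weaker inhibition than either, and the change to methyl is the first one at this position that clearly moves the read-out.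

On these data alone, what remains open is where between methyl and isopropyl the loss sets in, a question that an ethyl or a propyl group on the same oxygen would address. Also open, as far as these compounds go, are how far compound 3 truly lies from the other two, and whether a group of another kind on this oxygen, such as a chain ending in an amine or a carboxylic acid, would restore inhibition.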